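The source may report more compounds than this note shows. Statements on the series, on what has been measured and on what is new or still open speak of the compounds shown alone.

In an assay on CHO cells for inhibition of sphingosine kinase 1 (Homo sapiens), tested at 10 uM (a higher number here means more inhibition at the concentration tested (going by the name of the read-out), a lower number less inhibition), compound 2, `CCCCCCCCC#C[C@@H](O)[C@@H](N)CO`, gives 13.7%, the higher of the two numbers recorded. Compound 3, `CCCCCCCCC#CC(=O)[C@H](CO)NC(=O)OC(C)(C)C`, gives 4.2% in this assay, a value within the usual scatter of the number for compound 2, so the two cannot be ordered. Compound 1, `CCCCCCCCCCCCCC#C[C@@H](O)[C@@H]1COC(C)(C)N1C(=O)OC(C)(C)C`, is reported in this assay as "not active" (no number reported), with no number attached.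

Compound 4, `CCCCC#C[C@@H](O)[C@@H](N)CO`, is not yet measured. It differs from compound 2 by hydrogen in place of butyl on a saturated chain carbon, four bonds along the chain from a triple-bonded carbon. Going by the values given here, no step between measured compounds that differ in one place exists here, so the size of this one is unknown; on the numbers available, a change no larger than the scatter is expected, if anything a small loss. Compound 4 is accordingly estimated to give 8% in this assay, in a range from 0% to 20%, a step of a number 5.7 percentage points lower from compound 2 to compound 4 (within the scatter) expected from the value of compound 2.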

Compound 4, a percentage reported as inhibition, at one concentration (the size of the read-out at that concentration, not a potency): "not active" (no number reported)
No number was reported for compound 4, and the estimate cannot be compared.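

In this assay compound 4 carries no number, so no step can be read between compound 2 and compound 4. The compounds shown leave open what the butyl group contributes to inhibition. No evidence at hand bears on this result.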